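Ester for Amide on a Triazene: An Expected Potency

The source may report more compounds than this note shows. Statements on the series, on what has been measured and on what is new or still open speak of the compounds shown alone.

Compound 1 `CN(/N=N/c1ccc(C(N)=O)cc1)c1cccs1` gives 2.9 in a functional assay on L1210 cells (Mus musculus) for antiproliferative activity; a lower number here means a less potent compound, a higher number a more potent compound, by a factor of ten per unit of this negative logarithm.
Compound 2 `Cc1ccc(/N=N/N(C)C)cc1` gives 3.76.
Compound 3 `CN(C)/N=N/c1ccc(C(N)=O)cc1` gives 3.51.

Compound 3 stands second highest of the three numbers. Its nearest neighbour is compound 2, whose value lies within the scatter of its own, so no order can be read between the two. Compound 1 lies furthest away: a number 0.61 log units higher from compound 1 to compound 3 (beyond the scatter).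

Compound 4 `COC(=O)c1ccc(/N=N/N(C)C)cc1` has not yet been measured. It differs from compound 3 in one place: methoxy in place of amino on a carbonyl carbon. Among the measured compounds shown here, the only measured step that touches the same part of the molecule is the exchange on the aromatic carbon, a number 0.25 log units lower from compound 2 to compound 3 (within the scatter), which left the potency about where it was. For the measured compounds named here, no measured pair exchanges an amino for a methoxy on a carbonyl carbon, so the direction of the present change is not told by the data. The step of a number 0.01 log units lower from compound 3 to compound 4 (within the scatter) is expected to stay within the usual scatter, because a number 0.25 log units lower from compound 2 to compound 3 (within the scatter) showed that a change at that position moved the number little. Compound 4 is therefore expected to give 3.5, within a range from 3 to 4.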

Compound 4, logarithm of the reciprocal of the active concentration, log(1/C): 3.2
Estimate against measurement, compound 4: 0.30 log units above; measured number inside the range.
By their numbers in this assay, from the lowest: compounds 1 and 4 (each within the scatter of the next); then compounds 3 and 2 (each within the scatter of the next).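

In this assay, among the compounds shown here, the exchange of amino for methoxy on the carbonyl carbon gives a number 0.31 log units lower from compound 3 to compound 4 (beyond the scatter), the first step at this carbonyl group and one that reaches beyond the scatter. Starting from methyl on the aromatic carbon, methoxycarbonyl in its place gives a number 0.56 log units lower from compound 2 to compound 4 (beyond the scatter), while carbamoyl gave a number 0.25 log units lower from compound 2 to compound 3 (within the scatter), so the earlier small step did not mean that any group at this place leaves the number unchanged. Nothing available here accounts for the lower number of the ester, and no cause can be assigned to it.

The single exchange removes the amino group and brings in the methoxy group at once, so the compounds shown cannot tell whether the lower number goes with what left or with what entered. From the compounds shown here alone, it also remains open how a carboxylic acid, an ethyl ester with its longer chain, or an amide carrying a methyl on its nitrogen would read at this carbonyl carbon in this assay, and whether any of them would fall nearer to the amide or to the methyl ester.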